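The source may report more compounds than this note shows. Statements on the series, on what has been measured and on what is new or still open speak of the compounds shown alone.

Measured so far:
- compound 1, `Nc1scc(CN2CCN(c3ccc([N+](=O)[O-])cc3)CC2)c1C(=O)c1ccc(Cl)cc1`: -8.3%
- compound 2, `Nc1scc(CN2CCN(c3ccccc3C(F)(F)F)CC2)c1C(=O)c1ccc(Cl)cc1`: -39%

Both values come from a functional assay on CHO cells with adenosine receptor A1 (Homo sapiens) as the target, read by cAMP accumulation and immunoassay, with a stated time of 6 min, tested at 1 uM; a higher number here means a weaker effect of the compound at the concentration tested, a lower number a stronger effect. Within the data shown here, compound 1 stands at the higher of the two numbers; the only neighbour is compound 2, and the step between them is a number 30.7 percentage points lower from compound 1 to compound 2 (beyond the scatter). That single step, which swaps one aryl group for another on the ring amine nitrogen, is the whole of what the series shows so far.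

Compound 3, `Nc1scc(CN2CCN(CCCc3ccc(Cl)cc3)CC2)c1C(=O)c1ccc(Cl)cc1`, has not yet been measured in this assay. Its difference from compound 1 is 3-(4-chlorophenyl)propyl in place of 4-nitrophenyl on an amine nitrogen in a ring. Among the measured compounds shown here, no measured pair exchanges an aryl group for an alkyl chain on that nitrogen, so the step from compound 1 to compound 2 bears on compound 3 only loosely: it shows that a change at this position can move the read-out by a large amount, but not in which direction a chain will move it. The expectation is therefore a step of uncertain sign and moderate size, a number 11.7 percentage points lower from compound 1 to compound 3 (beyond the scatter), carrying broad uncertainty. Compound 3 is estimated to give -20%, with a range from -50% to 10%.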

Compound 3, a percentage reported as activity, at one concentration (the size of the read-out at that concentration, not a potency): -30%
Compound 3: middle estimate off by 10 percentage points, on the high side, and the stated range covers the measured number.
By their numbers in this assay, from the lowest: compounds 2 and 3 (each within the scatter of the next); then compound 1.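

In this assay, the change from an aryl group directly on the ring amine nitrogen to a chain carrying its aryl ring gives a number 21.7 percentage points lower from compound 1 to compound 3 (beyond the scatter) and moves the read-out the same way as the earlier aryl swap, so a lower number at this position is not confined to a second directly attached aryl group. Against the 2-(trifluoromethyl)phenyl group, the 3-(4-chlorophenyl)propyl group gives a number 9 percentage points higher from compound 2 to compound 3 (within the scatter) and these two quite different groups are not separated by this read-out, which leaves compound 1, with its 4-nitrophenyl group, alone apart from the other two. No measurement at hand offers an explanation for any of these steps.

The compounds shown leave open whether the shift seen with compound 3 depends on the chlorine, on the propyl length or on the terminal aromatic ring at all, which a shorter ethyl link, an unsubstituted phenyl end or a plain alkyl chain would help to separate. From the compounds shown here alone, it also remains open whether 4-nitrophenyl is a special case, a question that a simple phenyl group on the same nitrogen would address.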